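A few compounds are considered here, and "the series" means these few. Any claim that something is new, unique, unknown or untested is made for them only; others in the source may bear on it.

Measured compounds in an assay on isolated protein for displacement of a labelled ligand from 5-hydroxytryptamine receptor 6 (Homo sapiens); a lower number here means a stronger inhibitor, a higher number a weaker inhibitor:
compound 1 `O=S(=O)(c1cccc(F)c1)c1ccc2c(c1)CCC[C@H]2CN1CCCS1(=O)=O` gives 31.6 nM;
compound 2 `O=C(NC[C@@H]1CCCc2cc(S(=O)(=O)c3cccc(F)c3)ccc21)c1ccc[nH]1` gives 5.01 nM;
compound 3 `NC(=O)NC[C@@H]1CCCc2cc(S(=O)(=O)c3cccc(F)c3)ccc21` gives 0.2 nM.

Compound 3 has the lowest number of the three, and both gaps to it lie beyond the scatter: a 160-fold lower number from compound 1 to compound 3 (2.20 log units; beyond the scatter) and a 25-fold lower number from compound 2 to compound 3 (1.40 log units; beyond the scatter). Compound 4 `O=C(CO)NC[C@@H]1CCCc2cc(S(=O)(=O)c3cccc(F)c3)ccc21` has not been measured; it differs from compound 3 in one place: hydroxymethyl in place of amino on a carbonyl carbon. Among the measured compounds shown here, the only measured step that also changes the group on this carbonyl carbon is the large one from the pyrrolyl amide to the urea, so changing that group again is expected to move this assay noticeably, here towards a higher number, though the shared amide remains. Compound 4 is therefore expected to give 1 nM, with a range from 0.3 nM to 4 nM, an expected step of a 5.0-fold higher number from compound 3 to compound 4 (0.70 log units; beyond the scatter).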

Compound 4, inhibition constant: 0.1 nM
Compound 4: middle estimate off by 10-fold (1.00 log units), on the high side; measured number below the stated range.
By their numbers in this assay, from the lowest: compounds 4 and 3 (each within the scatter of the next); then compound 2; then compound 1.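

In this assay, hydroxymethyl in place of amino on this carbonyl carbon gives a 2.0-fold lower number from compound 3 to compound 4 (0.30 log units; within the scatter), so the two small groups cannot be told apart here, and the urea nitrogen is not needed for a number this low. Both ring-free groups stand clearly apart from the ring-bearing ones, with a 50-fold lower number from compound 2 to compound 4 (1.70 log units; beyond the scatter) and a 320-fold lower number from compound 1 to compound 4 (2.50 log units; beyond the scatter). Nothing available explains these differences.

Still open, going by these compounds, is whether a plain methyl group or a longer chain carrying the hydroxyl on this carbonyl carbon would keep the number this low.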